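A few compounds are considered here, and "the series" means these few. Any claim that something is new, unique, unknown or untested is made for them only; others in the source may bear on it.

Measured compounds: compound 1 `COc1cc(-c2nnc(SCC(=O)Nc3ccc(/C(C)=N/O)cc3)n2-c2ccccc2)cc(OC)c1OC` gives 70% in a functional assay on the whole organism (strain albino) for inhibition, with Rattus norvegicus as the target, read by paw edema, with stated times of 30 min and 5 h, at a dose of 0.28 mmol/kg by the oral route; on this read-out lower numbers stand for less inhibition and higher numbers for more inhibition at the one dose given (going by the name of the read-out); compound 2 `CCn1c(SCC(=O)Nc2ccc(C(C)=O)cc2)nnc1-c1ccc(OC)c(OC)c1` gives 66% in this assay; compound 3 `COc1ccc(-c2nnc(SCC(=O)Nc3ccc(/C(C)=N/O)cc3)n2-c2ccccc2)cc1OC` gives 76% in this assay.

The three measured values sit close together, and the step of a number 6 percentage points lower from compound 3 to compound 1 (within the scatter) lies within the scatter, so compound 3 and compound 1 cannot be told apart on this read-out. Compound 2 stands nearest to compound 1 and furthest from compound 3, yet both of those gaps are also within the scatter, so no order among the three is established. The change from compound 3 to compound 1 is methoxy in place of hydrogen on an aromatic carbon.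

Compound 4 `CCn1c(SCC(=O)Nc2ccc(C(C)=O)cc2)nnc1-c1cc(OC)c(OC)c(OC)c1` has not been measured. It differs from compound 2 by methoxy in place of hydrogen on an aromatic carbon, which is the same change as the one from compound 3 to compound 1; it appears twice among the compounds shown. The difference between the core of compound 2 and the core of compound 3 is not broken down here.

Since the single worked example of this change gave only a number 6 percentage points lower from compound 3 to compound 1 (within the scatter), compound 4 is expected to move by about a number 4 percentage points lower from compound 2 to compound 4 (within the scatter) from compound 2. Compound 4 is therefore estimated at 62% in this assay. Among the measured compounds shown here, for compound 4 the expected range runs from 50% to 74%, resting on the single measured step from compound 3 to compound 1 and on the scatter of this kind of measurement.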

Compound 4, a percentage reported as inhibition, in the whole organism at one dose (the size of the read-out at that dose, not a potency): 64%
Compound 4: the middle estimate sits 2 percentage points below what was measured; measured number inside the range.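

In this assay the added methoxy gives a number 2 percentage points lower from compound 2 to compound 4 (within the scatter), and set beside the earlier example of the same change, the two steps do not differ: the same change on two cores in this assay, a number 6 percentage points lower (within the scatter) from compound 3 to compound 1 and a number 2 percentage points lower (within the scatter) from compound 2 to compound 4, 4 percentage points apart, within the scatter of two such steps This shows that, on the two cores available, the change from hydrogen to methoxy on the aromatic carbon carries over from one core to the other without any difference that this read-out can resolve, and that on neither core does the step stand clear of the usual scatter. It does not show that methoxy has a real effect of a particular direction or size, or that it has none at all, and two steps within the scatter cannot establish a rule for other cores in the series or for other doses and read-outs.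

The compounds shown leave open whether a group other than methoxy in this place, such as a hydroxy group, an amine, a carboxylic acid or a longer alkoxy chain, would shift the inhibition of paw swelling beyond the scatter. They also leave open what each separate difference between the core of compound 2 and the core of compound 3 contributes, as those two compounds differ in more than one place.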